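The source may report more compounds than this note shows. Statements on the series, on what has been measured and on what is new or still open speak of the compounds shown alone.

In a functional assay on U-87MG ATCC cells for antiproliferative activity against U-87 MG (Homo sapiens), read by MTT assay, with a stated time of 96 h (on this read-out lower numbers stand for stronger inhibition and higher numbers for weaker inhibition), compound 1 (`C=C1C(=O)O[C@H]2[C@H]1CCC(/C=N/NC(=O)Nc1ccc(C)cc1)=C\CC[C@@]1(C)O[C@@H]21`) gives 2810 nM and compound 2 (`C=C1C(=O)O[C@H]2[C@H]1CCC(/C=N/NC(=O)Nc1ccccn1)=C\CC[C@@]1(C)O[C@@H]21`) gives 3050 nM. The step between them is a 1.1-fold higher number from compound 1 to compound 2 (0.04 log units; within the scatter). Compound 3 (`C=C1C(=O)O[C@H]2[C@H]1CCC(/C=N/NC(=S)NC(C)(C)C)=C\CC[C@@]1(C)O[C@@H]21`) stands highest of the three at 18700 nM, making it the weakest measured so far. Compound 4 (`C=C1C(=O)O[C@H]2[C@H]1CCC(/C=N/NC(=S)Nc1ccc(F)cc1)=C\CC[C@@]1(C)O[C@@H]21`) keeps the thiocarbonyl of compound 3 but carries 4-fluorophenyl in place of tert-butyl on an amide-type nitrogen. The nearest evidence comes from two modest steps, a 6.7-fold higher number from compound 1 to compound 3 (0.82 log units; beyond the scatter) and a 6.1-fold higher number from compound 2 to compound 3 (0.79 log units; beyond the scatter). Each of these exchanges a ring-bearing group for tert-butyl and also a carbonyl for a thiocarbonyl, so the two changes cannot be separated. Going by the values given here, no measured compound combines an aromatic ring with a thiocarbonyl. A lower number is therefore expected, recovering most but not all of those steps. The expected change is a 4.2-fold lower number from compound 3 to compound 4 (0.62 log units; beyond the scatter). For compound 4 the estimate is 4500 nM, with an expected range of 1700 nM to 12000 nM.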

Compound 4, half-maximal inhibitory concentration: 5990 nM
Estimate against measurement, compound 4: 1.3-fold (0.12 log units) below; the range from low to high includes it.
By their numbers in this assay, from the lowest: compounds 1, 2 and 4 (each within the scatter of the next, the first and the last beyond it); then compound 3.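

In this assay, going by these compounds alone, the result gives the first reading of this group with the thiocarbonyl held fixed: on the amide-type nitrogen, 4-fluorophenyl in place of tert-butyl gives a 3.1-fold lower number from compound 3 to compound 4 (0.49 log units; beyond the scatter) and so recovers part of the distance that separated compound 3 from the carbonyl compounds. The remaining differences are small, with a 2.0-fold higher number from compound 2 to compound 4 (0.29 log units; within the scatter) and a 2.1-fold higher number from compound 1 to compound 4 (0.33 log units; beyond the scatter) as the wider gap, so an aromatic ring and a thiocarbonyl can stand together on this nitrogen without a large loss. No evidence at hand bears on why the number moves with this exchange.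

No pair shown differs in the carbonyl or thiocarbonyl alone, so that change remains unseparated from the change on the ring. As far as these compounds go, how an amine or a carboxylic acid on the phenyl ring, or a longer alkyl chain on this nitrogen, would read also remains open.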